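Glycoside series: alkoxy for bromo on the phenol ring

A few compounds are considered here, and "the series" means these few. Any claim that something is new, unique, unknown or untested is made for them only; others in the source may bear on it.

Measured compounds:
Compound 1, `OC[C@H]1O[C@@H](OCCc2ccc(O)c(Br)c2)[C@H](O)[C@@H](O)[C@H]1O`, gives > 100000 nM in a functional assay, with a stated time of 30 min; a lower number here means a stronger inhibitor, a higher number a weaker inhibitor; this is a limit, not a number.
Compound 2, `OC[C@H]1O[C@@H](OCCc2cc(Br)c(O)c(Br)c2)[C@H](O)[C@@H](O)[C@H]1O`, gives > 100000 nM in this assay; again a limit.
Compound 3, `COc1cc(CCO[C@@H]2O[C@H](CO)[C@H](O)[C@H](O)[C@H]2O)cc(OC)c1O`, gives 70100 nM in this assay.

Compound 1 stands at the limit of this assay; its value is one of the two limits among the three values shown, as the limit of > 100000 nM in this assay, at which 2 of the 3 values shown sit, states. The step that the two limits leave unreadable from compound 1 to compound 2 is a step that both limits leave unreadable, so it gives no size. Among the compounds with values here, no measured step joins compound 1 to compound 3.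

Compound 4, `CCOc1cc(CCO[C@@H]2O[C@H](CO)[C@H](O)[C@H](O)[C@H]2O)ccc1O`, differs from compound 1 by ethoxy in place of bromo on an aromatic carbon.

Within the data shown here, no measured step bears directly on this change. Among the measured compounds shown here, the only numeric value is that of compound 3, and it sits close to the limit. Compound 4 is therefore expected to remain near the limit, with a step of a number no higher from compound 1 to compound 4 (the limit leaves the size open) that cannot be read as a real gain. The estimate for compound 4 is 100000 nM, in the range 30000 nM to 300000 nM.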

Compound 4, half-maximal inhibitory concentration: 87500 nM
Compound 4: middle estimate off by 1.1-fold (0.06 log units), on the high side, within the range that was stated.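

Unlike bromo, ethoxy on this aromatic carbon, ortho to a hydroxy group, yields a readable number: in this assay, compound 4 gives 87500 nM. The change gives an at least 1.1-fold lower number from compound 1 to compound 4 (0.05 log units; that floor lies within the scatter), so a real gain is not established. The true size of this step stays open because compound 1 sits at a limit: the limit of > 100000 nM in this assay, at which 2 of the 4 values shown sit.

The compounds shown leave open how the number moves with a longer alkoxy chain such as butoxy, or with an amine or a carboxylic acid on this carbon. They also leave open whether any change at this position can give a value clearly separated from the limit of the assay.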